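The source may report more compounds than this note shows. Statements on the series, on what has been measured and on what is new or still open speak of the compounds shown alone.

Working notes on the quaternary-chain series, read in an assay on LX2 cells for inhibition of COL1A1 promoter (Homo sapiens), read by a luciferase reporter, with a stated time of 24 h, tested at 20 uM; a lower number here means a weaker effect, a higher number a stronger effect of the compound at the concentration tested. Compound 1 `Cc1ccc(-n2cc(C(=O)Nc3cc(F)cc(F)c3)c(=O)c3ccc(N(C)C)nc32)cc1OCCCCCCC[N+]12CCN(CC1)CC2` gives 5.07%. Compound 2 `Cc1ccc(-n2cc(C(=O)Nc3cc(F)cc(F)c3)c(=O)c3ccc(N(C)C)nc32)cc1OCCCCCCC[N+]1(C)CCCCC1` gives 23.4%. Compound 3 `CN(C)c1ccc2c(=O)c(C(=O)Nc3cc(F)cc(F)c3)cn(-c3ccc(Cl)c(OCCCCCCC[N+]4(C)CCCCC4)c3)c2n1` gives 57.3%. Among these three numbers compound 2 stands second highest: the step of a number 18.3 percentage points higher from compound 1 to compound 2 (beyond the scatter) separates it from compound 1 beneath, and the step of a number 33.9 percentage points higher from compound 2 to compound 3 (beyond the scatter) separates it from compound 3 above.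

Compound 4 `CC[N+]1(CCCCCCCOc2cc(-n3cc(C(=O)Nc4cc(F)cc(F)c4)c(=O)c4ccc(N(C)C)nc43)ccc2C)CCCC1` differs from compound 2 only at the charged end of the chain:
a group of 7 heavy atoms (6 carbon, 1 nitrogen; one five-membered non-aromatic ring with 1 hetero atom) in place of a group of 7 heavy atoms (6 carbon, 1 nitrogen; one six-membered non-aromatic ring with 1 hetero atom), on a saturated chain carbon, seven bonds along the chain from an oxygen on an aromatic ring

For the measured compounds named here, of the measured steps, only the one from compound 1 to compound 2 bears on this change, since it sits at the same place on the chain; it was modest, and the group exchange it describes is the deeper one, whereas the present change keeps the same atoms and the same charge and alters only the ring size. The step from compound 2 to compound 3 concerns a substituent on an aromatic carbon and carries no information about the chain terminus. In this assay a small step is therefore expected, without a clear direction and probably within the scatter. The expected step is estimated as a number 1.6 percentage points higher from compound 2 to compound 4 (within the scatter). Compound 4 is accordingly expected to give about 25%, with a range from 10% to 42%.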

Compound 4, a percentage reported as inhibition, at one concentration (the size of the read-out at that concentration, not a potency): 57%
Compound 4: the middle estimate sits 32 percentage points below what was measured; the whole stated range lies below it.
By their numbers in this assay, from the lowest: compound 1; then compound 2; then compounds 4 and 3 (each within the scatter of the next).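

At the charged end of the chain, on a saturated chain carbon seven bonds along the chain from an oxygen on an aromatic ring, the read-out in this assay depends on more than heavy-atom count and net charge: a number 33.6 percentage points higher from compound 2 to compound 4 (beyond the scatter), although the five-membered non-aromatic ring group that enters and the six-membered one that leaves have the same atoms and both carry a net charge of +1. Across the three terminal groups on the shared core with the aromatic methyl, a number 51.9 percentage points higher from compound 1 to compound 4 (beyond the scatter), so this one position alone spans a large range of the read-out at the concentration tested. Nothing shown here gives a reason for either step.

The two groups are joined differently in more than ring size, so these compounds do not show whether the five-membered ring itself accounts for the step or whether the other substituents on the charged nitrogen contribute. Also open, as far as these compounds go, is how a seven-membered azepane ring or a morpholine ring at this chain end would read, and whether the five-membered ring group gives a similar step with chloro in place of methyl on the aromatic carbon.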